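Bromophenyl Sulfonyl in Place of Nitrophenyl Sulfonyl

This account rests on a few compounds, and the source may have more. Where it says the series, first, only, none or still open, it means among the compounds named here.

Compound 1 `COC(=O)c1cc(=O)c2c(OC)cc(OC)cc2[nH]1` gives > 34400 nM in a functional assay on KOPN-8 cells (Homo sapiens) for antiproliferative activity, with a stated time of 72 h (a lower number here means that less compound is needed, a higher number that more compound is needed for the effect), which is a limit of this assay and not a number.
Compound 2 `COC(=O)c1cc(=O)c2cc(N)ccc2[nH]1` gives > 33700 nM in this assay, again a limit.
Compound 3 `COc1ccc(-c2cc(=O)c3c(OC)cc(OC)cc3n2S(=O)(=O)c2ccc([N+](=O)[O-])cc2)cc1` gives 17300 nM in this assay.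

Going by the values given here, compound 3 thus stands as the only compound with a number in this assay; the other two values sit at limits, namely the limit of > 33700 nM in this assay, at which 1 of the 3 values shown sits, and (the limit of > 34400 nM in this assay, at which 1 of the 3 values shown sits). Compound 4 `COc1ccc(-c2cc(=O)c3c(OC)cc(OC)cc3n2S(=O)(=O)c2cccc(Br)c2)cc1` arises from compound 3 by one change: 3-bromophenyl in place of 4-nitrophenyl on a sulfonyl sulfur. Among the compounds with values here, no measured pair in this set differs in one place, so there is nothing to show how an exchange at the sulfonyl sulfur moves the read-out. The change removes two hydrogen-bond acceptors and brings in a bromine, but no shown step tells its effect. Compound 4 is therefore expected to stay close to compound 3, with the step of a 1.2-fold lower number from compound 3 to compound 4 (0.06 log units; within the scatter) expected to lie within the scatter, and its half-maximal effective concentration is estimated at 15000 nM (range 5000 nM to 45000 nM).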

Compound 4, half-maximal effective concentration: > 58600 nM
Compound 4 gave a limit, no number; the forecaster's own chance of this, stated with the estimate: 25%; at least 3.9-fold (0.59 log units) between middle value and limit.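

This first step at the sulfonyl sulfur shows that the exchange is not neutral in this assay: 3-bromophenyl in place of 4-nitrophenyl gives an at least 3.3-fold higher number from compound 3 to compound 4 (0.52 log units; beyond the scatter). Of these two groups on the sulfonyl sulfur, 4-nitrophenyl goes with the lower number. The true size of the step stays unknown, as compound 4 sits at a limit and not at a number: the limit of > 58600 nM in this assay, at which 1 of the 4 values shown sits.

The compounds shown leave open whether the step follows from losing the nitro group, from the bromine, or from where the substituent sits on the ring. They also do not tell how a 4-aminophenyl or 4-carboxyphenyl group on the sulfonyl sulfur would read.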